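Truncating the thioacetal side chain of compound 2

The compounds below may be only part of what the source reports. "The series", "measured", "known", "first", "only" and "open" are said of these compounds alone.

Compound 2 `CCCCSCSCC1C2CCC(O2)C1C/C=C\CCCC(=O)O` gives 700 nM in a functional assay on a cell-free system (plasma) for inhibition of thromboxane A2 receptor (Homo sapiens) (on this read-out higher numbers stand for weaker inhibition and lower numbers for stronger inhibition), the lowest of the two numbers available. Compound 3 `CCCCCCS(=O)(=O)CC1C2CCC(O2)C1C/C=C\CCCC(=O)O` gives 25000 nM in this assay, a higher number beyond the scatter. Compound 1 `CCCCCCSC[C@H]1C2CC[C@@H](O2)[C@H]1C/C=C\CCCC(=O)O` returns 115000 nM; > 1000000 nM; > 1000000 nM (3 entries) in this assay across its three entries. Compound 4 `CCSCC1C2CCC(O2)C1C/C=C\CCCC(=O)O` is not yet measured; it differs from compound 2 by methyl in place of butylsulfanyl on a saturated chain carbon bound to a sulfur. Among the compounds with values here, no measured step covers this change. Given the long-chain analogues compound 1 and compound 3 both giving weak numbers, a loss is expected, and the step from compound 2 to compound 4 is estimated at a 7.1-fold higher number from compound 2 to compound 4 (0.85 log units; beyond the scatter). Compound 4 is expected to give about 5000 nM in this assay, within 1000 nM to 50000 nM.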

Compound 4, half-maximal inhibitory concentration: 5400 nM
For compound 4 the middle estimate is 1.1-fold (0.03 log units) below the measured one, and the stated range covers the measured number.
By their numbers in this assay, from the lowest: compound 2; then compound 4; then compound 3.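

Replacing butylsulfanyl with methyl on a saturated chain carbon bound to a sulfur gives a 7.7-fold higher number from compound 2 to compound 4 (0.89 log units; beyond the scatter) in this assay. Within the data shown here, this is the first measured step at this position and shows that the butylsulfanyl group matters to the read-out, although compound 4, with the shorter chain, still gives a defined number. Nothing shown here gives a cause for this step.

Going by these compounds, how a propyl chain would read at this place remains open. So do an ether oxygen in place of the outer sulfur and a terminal amine on the chain.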